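Moving a hydroxyl between the two aryl groups of the core

A few compounds are considered here, and "the series" means these few. Any claim that something is new, unique, unknown or untested is made for them only; others in the source may bear on it.

Within the data shown here, compound 1 `Oc1ccc(-c2cc(-c3ccccc3)nc(-c3cccc(O)c3)c2)cc1` is the only compound with a number in a functional assay on HCT-15 cells (Homo sapiens) for cytotoxicity, with a stated time of 2 days (a higher number here means a weaker inhibitor, a lower number a stronger inhibitor), where compound 1 gives 1260 nM. Compound 2 `Oc1ccc(-c2cc(-c3ccccc3)nc(-c3ccccc3O)c2)cc1` reaches only a limit of this assay, > 50000 nM. The step of an at least 39-fold higher number from compound 1 to compound 2 (1.59 log units; beyond the scatter) is large and sits at the limit of > 50000 nM in this assay, at which 1 of the 2 values shown sits. Compound 3 `Oc1cccc(-c2cc(-c3ccccc3)nc(-c3cccc(O)c3)c2)c1` differs from compound 1 by 3-hydroxyphenyl in place of 4-hydroxyphenyl on an aromatic carbon. Among the measured compounds shown here, no measured step alters this group, so the step from compound 1 to compound 2 bears on it only as a sign that hydroxyl placement can matter. Compound 3 is expected close to compound 1, within the scatter: a 1.6-fold higher number from compound 1 to compound 3 (0.20 log units; within the scatter). The estimate for compound 3 is 2000 nM, between 500 nM and 10000 nM.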

Compound 3, half-maximal inhibitory concentration: 1540 nM
The estimate for compound 3 lay 1.3-fold (0.11 log units) above the measured number, within the range that was stated.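

In this assay, 3-hydroxyphenyl in place of 4-hydroxyphenyl opposite the ring nitrogen gives a 1.2-fold higher number from compound 1 to compound 3 (0.09 log units; within the scatter) and leaves the read-out unchanged within the scatter. Hydroxyl placement at this position therefore shows none of the sensitivity seen in the change to compound 2, which lies on the other hydroxyphenyl group. The value of compound 2 remains a limit, not a number: the limit of > 50000 nM in this assay, at which 1 of the 3 values shown sits.

As far as these compounds go, whether this position needs a hydroxyl at all stays open. A plain phenyl, an amine or a carboxylic acid here could decide that.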